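The source may hold more compounds than are shown below. What is called first, only, known or untested is meant among the compounds shown, and "the series" means these compounds.

Compound 1, with the structure `O=C(C1CC1)N1CCc2nc(C#Cc3ccccc3)sc2C1`, carries a cyclopropyl group on its carbonyl carbon, and in an assay on HEK293 cells for negative allosteric modulation of metabotropic glutamate receptor 5 (Homo sapiens), read by FLIPR, with a stated time of 1 h (a lower number here means a stronger inhibitor, a higher number a weaker inhibitor), compound 1 gives 290 nM. Compound 2, with the structure `O=C(C1CCCCC1)N1CCc2nc(C#Cc3ccccc3)sc2C1`, differs only in that a cyclohexyl group replaces the cyclopropyl. For compound 2 this assay reports only a limit, > 10000 nM, so no exact number is known for it. The step of an at least 34-fold higher number from compound 1 to compound 2 (1.53 log units; beyond the scatter) is therefore at least as large as the limit allows; it rests on (the limit of > 10000 nM in this assay, at which 1 of the 2 values shown sits), one of the two values shown. Compound 2 thus stands at the weak end of the pair.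

Compound 3, with the structure `O=S(=O)(C1CC1)N1CCc2nc(C#Cc3ccccc3)sc2C1`, is reached from compound 2 by the change (cyclopropylsulfonyl in place of cyclohexylcarbonyl on an amine nitrogen in a ring). This change brings back the three-membered ring of compound 1 while swapping the carbonyl for a sulfonyl. The only measured step bearing on it is an at least 34-fold higher number from compound 1 to compound 2 (1.53 log units; beyond the scatter), which shows that going from cyclopropyl to cyclohexyl costs a great deal; the reverse move is expected to recover much of that loss, while the effect of the sulfonyl in place of the carbonyl is unknown from the compounds shown. In this assay compound 3 is therefore expected to give about 700 nM, in the range 150 nM to 4000 nM, a step of an at least 14-fold lower number from compound 2 to compound 3 (1.15 log units; beyond the scatter) expected to lie beyond the scatter.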

Compound 3, half-maximal inhibitory concentration: 34 nM
Compound 3: the middle estimate sits 21-fold (1.31 log units) above what was measured; the whole stated range lies above it.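

With the cyclopropyl group kept, putting cyclopropylsulfonyl in place of cyclopropylcarbonyl on the amine nitrogen in a ring gives an 8.5-fold lower number from compound 1 to compound 3 (0.93 log units; beyond the scatter). Going by these compounds alone, the earlier pair varied only the ring on the carbonyl, so this is the first sign that the unit joining that ring to the shared core matters in its own right, and in this assay compound 3 is the strongest of the three, with both of its steps beyond the scatter. The full exchange of cyclohexylcarbonyl for cyclopropylsulfonyl gives an at least 290-fold lower number from compound 2 to compound 3 (2.46 log units; beyond the scatter), but one end of that step is a limit and not a number, so its true size stays unknown: the limit of > 10000 nM in this assay, at which 1 of the 3 values shown sits.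

The compounds shown leave open whether a cyclohexyl group on the sulfonyl would suffer the same large loss as it does on the carbonyl, since the ring and the linking unit change together in the step between the cyclohexylcarbonyl and cyclopropylsulfonyl compounds. Also open, from the compounds shown here alone, is how smaller or intermediate groups on the sulfonyl, such as a methyl or a cyclobutyl, would read in this assay.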